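This account rests on a few compounds, and the source may have more. Where it says the series, first, only, none or still open, it means among the compounds named here.

Measured compounds:
compound 1, `N#CC1=C(NC(=O)/C=C/c2ccccc2)N(c2ccc(S(N)(=O)=O)cc2)C2=C(C(=O)CCC2)C1c1ccc(Cl)cc1Cl`: 40%
compound 2, `NC(=O)C1=C(N)N(c2ccc(S(N)(=O)=O)cc2)C2=C(C(=O)CCC2)C1c1ccc(Cl)cc1Cl`: 40%
compound 3, `NC1=C(C(=O)O)C(c2ccc(Cl)cc2Cl)C2=C(CCCC2=O)N1c1ccc(S(N)(=O)=O)cc1`: 10%

All three were tested in a functional assay on Ehrlich cells (Mus musculus) for cytotoxicity, read by trypan blue exclusion, with a stated time of 2 h, tested at 50 ug/mL; a higher number here means a stronger effect of the compound at the concentration tested, a lower number a weaker effect. Compound 1 sits level with compound 2 at the digits reported, and the two together stand above compound 3. Going by the values given here, the one step that is known, a number 30 percentage points lower from compound 2 to compound 3 (beyond the scatter), concerns a change of a carbonyl substituent on the shared core and not the group attached through the amide-type nitrogen.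

Compound 4, `CC(=O)CC(=O)NC1=C(C#N)C(c2ccc(Cl)cc2Cl)C2=C(CCCC2=O)N1c1ccc(S(N)(=O)=O)cc1`, is compound 1 with a different chain on the amide-type carbonyl: 2-oxopropyl in place of 2-phenylethenyl on a carbonyl carbon. Among the compounds with values here, no measured pair shows the effect of changing this chain, so the step from compound 2 to compound 3 bears on it only indirectly, as a sign that changes of a carbonyl substituent on this core can move the read-out by a modest amount. With nothing else to go on, the expectation for compound 4 is a step of about a number 5 percentage points lower from compound 1 to compound 4 (within the scatter), that is, no change beyond the usual scatter in this assay. Compound 4 is therefore estimated at 35%, with a range from 15% to 55%.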

Compound 4, a percentage reported as activity, at one concentration (the size of the read-out at that concentration, not a potency): 60%
Compound 4: middle estimate off by 25 percentage points, on the low side, outside the stated range (above it).
By their numbers in this assay, from the lowest: compound 3; then compounds 1 and 2 (each within the scatter of the next); then compound 4.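

Compound 4 shows that the chain on this carbonyl carbon, whose other neighbour is the amide-type nitrogen, can move the read-out: in this assay, putting 2-oxopropyl in place of 2-phenylethenyl gives a number 20 percentage points higher from compound 1 to compound 4 (beyond the scatter). Going by these compounds alone, this is the first measured step at this place, and it shows that the six-membered aromatic ring of 2-phenylethenyl is not needed here for an effect of this size, since the smaller 2-oxopropyl chain has no ring at all. The change removes the ring, shortens the chain and adds a hydrogen-bond acceptor all at once, and no measurement available here gives a reason for the step.

The compounds shown leave open whether the higher number goes with the loss of the ring or with the oxygen of 2-oxopropyl; a plain propyl chain at this place, compared with compound 4, would begin to separate the two. Also open, as far as these compounds go, is how a longer chain or an amine on this carbonyl carbon would read, and whether the order seen at this single concentration would hold at others.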